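Naphthalene in place of phenyl on the thienopyrimidinone core

This account rests on a few compounds, and the source may have more. Where it says the series, first, only, none or still open, it means among the compounds named here.

Of the compounds shown here, two have been measured in a functional assay on MDA-MB-231 cells (Homo sapiens) for inhibition, read by MTT assay, with a stated time of 48 h; on this read-out lower numbers stand for stronger inhibition and higher numbers for weaker inhibition. Compound 1 `O=C(Cn1cnc2scc(-c3ccc(Cl)cc3)c2c1=O)N/N=C/c1ccc(Cl)c([N+](=O)[O-])c1` gives 32000 nM. Compound 2 `O=C(Cn1cnc2scc(-c3ccccc3)c2c1=O)N/N=C/c1ccc(Cl)c([N+](=O)[O-])c1`, which carries hydrogen in place of chloro on an aromatic carbon, gives 20000 nM. The only measured step, a 1.6-fold lower number from compound 1 to compound 2 (0.20 log units; within the scatter), is within the scatter, so on the numbers shown compound 2 and compound 1 cannot be told apart, and compound 2 is simply one of two closely placed values.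

Compound 3 `O=C(Cn1cnc2scc(-c3ccc4ccccc4c3)c2c1=O)N/N=C/c1ccc(Cl)c([N+](=O)[O-])c1` differs from compound 2 by naphthalen-2-yl in place of phenyl on an aromatic carbon. Within the data shown here, no measured step bears directly on this change: the one step known concerns a substituent on the distant aryl ring, not the group on the fused core. Without a comparable precedent, no shift beyond the scatter in this assay is expected in either direction. Compound 3 is therefore estimated at 20000 nM, with a range from 7000 nM to 60000 nM, which corresponds to an expected step of no change at the digits printed from compound 2 to compound 3 (within the scatter).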

Compound 3, half-maximal inhibitory concentration: 20000 nM
Beside the measured number, compound 3's estimate shows no gap at the digits printed; the range from low to high includes it.
By their numbers in this assay, from the lowest: compounds 2, 3 and 1 (each within the scatter of the next).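

In this assay, the step from phenyl to naphthalen-2-yl gives no change at the digits printed from compound 2 to compound 3 (within the scatter), and the step from 4-chlorophenyl to naphthalen-2-yl gives a 1.6-fold lower number from compound 1 to compound 3 (0.20 log units; within the scatter). This position on the five-membered aromatic ring has now carried a second six-membered aromatic ring, and the values of all three compounds remain within the scatter of one another, so none of these aromatic groups can be told apart on this read-out. No supporting data bear on why the values stay so close.

From the compounds shown here alone, all three compounds carry an aromatic group of carbon only at this position, so it remains open whether an amine or a carboxylic acid there would separate from these values. The effect of removing the nitro group, which all three share, is also left open.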